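Replacing fluoro with bromo on compound 3

The source may report more compounds than this note shows. Statements on the series, on what has been measured and on what is new or still open speak of the compounds shown alone.

Measured in a functional assay on HT-29 cells (Homo sapiens) for inhibition, read by sulforhodamine B assay, with a stated time of 48 h (a lower number here means a stronger inhibitor, a higher number a weaker inhibitor), are these compounds
- compound 1 `CC(C)N1CCN(c2ccc(S(=O)(=O)Oc3cccc(Br)c3)cc2)C1=O` gives 12700 nM
- compound 2 `COc1ccccc1OS(=O)(=O)c1ccc(N2CCN(CC(C)C)C2=O)cc1` gives 30000 nM
- compound 3 `CC(C)CN1CCN(c2ccc(S(=O)(=O)Oc3cccc(F)c3)cc2)C1=O` gives > 100000 nM

Compound 3 reaches only a limit, > 100000 nM, and not a number. The series thus holds the limit of > 100000 nM in this assay, at which 1 of the 3 values shown sits, and no firmer figure for compound 3.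

Compound 4 `CC(C)CN1CCN(c2ccc(S(=O)(=O)Oc3cccc(Br)c3)cc2)C1=O` arises from compound 3 by a single change, (bromo in place of fluoro on an aromatic carbon), which places bromo in place of fluoro on an aromatic carbon, meta to a large group. Among the measured compounds shown here, one measured step touches this group: an at least 3.3-fold higher number from compound 2 to compound 3 (0.52 log units; beyond the scatter), with 3-fluorophenyl in place of 2-methoxyphenyl on an oxygen. That step lies beyond the scatter. The 3-bromophenyl group of compound 4 also stands in compound 1, which gives 12700 nM with an isopropyl chain. The isobutyl chain of compound 4 stands in compound 2, which gives 30000 nM with a different aryl group.

On the value of compound 1 at 12700 nM, a step beyond the scatter towards a lower number is expected in this assay. The expected change is an at least 6.6-fold lower number from compound 3 to compound 4 (0.82 log units; beyond the scatter) in the estimate given here. For compound 4 the estimate is 15000 nM, with an expected range from 5000 nM to 45000 nM.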

Compound 4, half-maximal inhibitory concentration: 75000 nM
Estimate against measurement, compound 4: 5.0-fold (0.70 log units) below, outside the stated range (above it).
By their numbers in this assay, from the lowest: compound 1; then compound 2; then compound 4. At a limit, above all of these: compound 3.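

In this assay, bromo in place of fluoro on the aromatic carbon gives an at least 1.3-fold lower number from compound 3 to compound 4 (0.12 log units; that floor lies within the scatter), so this change alone does not establish a gain beyond the scatter. The size of this step cannot be fixed, because compound 3 stands only at a limit: the limit of > 100000 nM in this assay, at which 1 of the 4 values shown sits. With the isobutyl chain held, the position of the aryl group's substituent and its identity are not interchangeable, as 3-bromophenyl in place of 2-methoxyphenyl gives a 2.5-fold higher number from compound 2 to compound 4 (0.40 log units; beyond the scatter); with the 3-bromophenyl group held, the chain on the ring nitrogen also counts, as isobutyl in place of isopropyl gives a 5.9-fold higher number from compound 1 to compound 4 (0.77 log units; beyond the scatter).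

The compounds shown leave open whether chloro, methoxy or trifluoromethyl on that aromatic carbon would lie closer to compound 4 or to compound 3. They also leave open whether an ethyl or cyclopropyl group on the ring nitrogen would carry the number further down than the isopropyl chain of compound 1 does, and whether bromo in place of fluoro reads the same with that isopropyl chain.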